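From a nitrile to two chlorines on the pendant phenyl

The source may hold more compounds than are shown below. What is called first, only, known or untested is meant among the compounds shown, and "the series" means these compounds.

Of the compounds shown here, two have been measured in an assay for displacement of a labelled ligand from melanin-concentrating hormone receptor 1 (Homo sapiens), read by fluorescence; a higher number here means a weaker inhibitor, a lower number a stronger inhibitor. Compound 1 `CC(=O)Nc1cccc(C2CCN(CCCn3c(-c4ccccc4C(F)(F)F)nc4ccccc43)CC2)c1` gives 50 nM in this assay, while compound 2 `CC(=O)Nc1cccc(C2CCN(CCCn3c(-c4ccc(C#N)cc4)nc4ccccc43)CC2)c1` gives 16 nM. Within the data shown here, the one step between them, a 3.1-fold lower number from compound 1 to compound 2 (0.49 log units; beyond the scatter), places compound 2 with the lowest of the two numbers, its only neighbour being compound 1 a modest but real distance away.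

Compound 3 `CC(=O)Nc1cccc(C2CCN(CCCn3c(-c4ccc(Cl)cc4Cl)nc4ccccc43)CC2)c1` has not yet been measured. It differs from compound 2 by 2,4-dichlorophenyl in place of 4-cyanophenyl on an aromatic carbon. Among the measured compounds shown here, only the step from compound 1 to compound 2 bears on this change, and it is an imperfect guide: that step changed the group and its placement on the phenyl at once, whereas the 2,4-dichlorophenyl of compound 3 shares its pattern partly with the 2-(trifluoromethyl)phenyl of compound 1 and partly with the 4-cyanophenyl of compound 2. The expectation for compound 3 is therefore a number between those two, most likely a small rise from compound 2, a 1.9-fold higher number from compound 2 to compound 3 (0.27 log units; within the scatter), that may or may not exceed the scatter. Compound 3 is estimated at 30 nM in this assay, within a range of 10 nM to 100 nM.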

Compound 3, half-maximal inhibitory concentration: 3 nM
Beside the measured number, compound 3's estimate is 10-fold (1.00 log units) above it; the measured number lies below the stated range.
By their numbers in this assay, from the lowest: compound 3; then compound 2; then compound 1.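

The result shows that this place, the aromatic carbon between two ring nitrogen atoms, can give a much lower number in this assay than the 4-cyanophenyl group had suggested: there is a 5.3-fold lower number from compound 2 to compound 3 (0.73 log units; beyond the scatter), and a 17-fold lower number from compound 1 to compound 3 (1.22 log units; beyond the scatter), a large step that now spans the three groups measured there. Compound 3 reaches the lowest number of the series with a group that counts no hydrogen-bond acceptor, so among these compounds the acceptor counted in the 4-cyanophenyl of compound 2 is not needed for a low number. No measurement is available to explain why the 2,4-dichlorophenyl group does better than either of the other two groups.

The compounds shown do not separate the contributions of the two chlorines, so it remains open how a 2-chlorophenyl or a 4-chlorophenyl group alone would compare with the 2,4-dichlorophenyl of compound 3. On these data alone, it also remains open whether a methoxy group or an amine on the same phenyl would hold the number as low as compound 3 does, and whether the gain would persist with a longer chain in place of the propyl linker.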